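The compounds below may be only part of what the source reports. "The series", "measured", "known", "first", "only" and "open" are said of these compounds alone.

Measured compounds in the series:

compound 1 `CC(C)=CCCN(C)C1CCN(CCCc2c[nH]c3ccc(-n4cnnc4)cc23)CC1` — 24 nM
compound 2 `OC[C@H](NC1CCN(CCCc2c[nH]c3ccc(-n4ccnc4)cc23)CC1)c1ccccc1` — 100 nM
compound 3 `C[C@@H](NC1CCN(CCCc2c[nH]c3ccc(-n4ccnc4)cc23)CC1)c1ccccc1` — 110 nM

All three were run in an assay on CHO cells for displacement of a labelled ligand from 5-hydroxytryptamine receptor 1B (Homo sapiens); a higher number here means a weaker inhibitor, a lower number a stronger inhibitor. Within the data shown here, compound 1 gives the lowest number of the three, and the gaps from compound 1 to compound 2 and to compound 3 are both beyond the scatter; no single-change step connects compound 1 with either of them, since the two differ from it in more than one place.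

Among the measured compounds shown here, the one counted step, a 1.1-fold higher number from compound 2 to compound 3 (0.04 log units; within the scatter), concerns the substituent on the amine nitrogen and lies within the scatter, so in that pair the amine substituent could be altered without a change in the read-out.

Compound 4 `c1ccc2c(c1)CCC2NCC1CCN(CCCc2c[nH]c3ccc(-n4cnnc4)cc23)CC1` is the next compound to be measured. It differs from compound 1 by ((2,3-dihydro-1H-inden-1-yl)amino)methyl in place of methyl(4-methylpent-3-en-1-yl)amino on a saturated ring carbon. For the measured compounds named here, this is a larger alteration than the one measured step, and it is taken from the compound with the lowest number; the new substitution pattern is closer in character to those of compound 2 and compound 3. The expected step is therefore a 2.1-fold higher number from compound 1 to compound 4 (0.32 log units; beyond the scatter), toward a higher number but of modest size. Compound 4 is estimated at 50 nM, with a range from 15 nM to 200 nM.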

Compound 4, half-maximal inhibitory concentration: 25 nM
Estimate against measurement, compound 4: 2.0-fold (0.30 log units) above; low and high end bracket the measured number.
By their numbers in this assay, from the lowest: compounds 1 and 4 (each within the scatter of the next); then compounds 2 and 3 (each within the scatter of the next).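

In this assay, the exchange on the saturated ring carbon, three ring bonds from the ring nitrogen, gives a 1.0-fold higher number from compound 1 to compound 4 (0.02 log units; within the scatter), the first single-change step from the compound with the lowest number. In this pair the read-out therefore does not depend on the open-chain methyl(4-methylpent-3-en-1-yl)amino group: ((2,3-dihydro-1H-inden-1-yl)amino)methyl, which is larger, carries a five-membered and a six-membered ring and a hydrogen-bond donor, and loses the double bond outside aromatic rings, serves equally well, so the low end of the series now rests on two different substituents at this position. The data on hand offer nothing that explains why so large an exchange leaves the number in place.

Compounds 2 and 3 each differ from compounds 1 and 4 in more than one place, so the gap to them cannot be assigned to any single change. Also open, as far as these compounds go, is how far this tolerance extends, for example whether a carboxylic acid or a plain primary amine on the same saturated ring carbon would hold the number.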